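The compounds below may be only part of what the source reports. "The series", "measured", "known", "first", "only" and "open" are said of these compounds alone.

Measured so far in an ADME assay on A549 cells (Homo sapiens) for cytotoxicity, read by CellTiter-Glo; on this read-out lower numbers stand for higher toxicity in this test and higher numbers for lower toxicity in this test:
Compound 1 `Cc1c(Cc2ccccc2)c(=O)oc2cc(OCC(O)CNc3cc([N+](=O)[O-])ccc3O)ccc12`: > 100000 nM, a limit of the assay.
Compound 2 `Cc1c(Cc2ccccc2)c(=O)oc2cc(OCC(O)CNC3CCOCC3)ccc12`: 38200 nM.
Compound 3 `Cc1c(Cc2cccc(F)c2)c(=O)oc2cc(OCC(O)CN3CCC(C(N)=O)CC3)ccc12`: 53300 nM.

Compound 3 gives the highest of the two plain numbers in this assay; compound 2 lies closest to it, and the gap between the two is within the scatter. Compound 1 sits at the limit of the assay, as the limit of > 100000 nM in this assay, at which 1 of the 3 values shown sits, records.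

Compound 4 `Cc1c(Cc2ccccc2C(F)(F)F)c(=O)oc2cc(OCC(O)CN3CCC(C(N)=O)CC3)ccc12` differs from compound 3 in one place: 2-(trifluoromethyl)phenyl in place of 3-fluorophenyl on a saturated chain carbon bound to an aromatic carbon. Among the compounds with values here, the only measured step, an at least 2.6-fold lower number from compound 1 to compound 2 (0.41 log units; beyond the scatter), concerns the substituent on the amine nitrogen and not the aryl group on the saturated chain carbon, so no measured step bears directly on the change from compound 3 to compound 4. Compound 2 and compound 3, which differ both at the amine and at the aryl group, sit within the scatter of each other in this assay, and that is the nearest indication that the aryl group has little effect on this read-out.

Compound 4 is therefore expected to show a step of about a 1.1-fold lower number from compound 3 to compound 4 (0.03 log units; within the scatter), that is, no change beyond the scatter. The estimate for compound 4 in this assay is 50000 nM, with a range from 22000 nM to 100000 nM.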

Compound 4, half-maximal cytotoxic concentration: > 100000 nM
Compound 4 gave a limit, no number; the forecaster's own chance of this, stated with the estimate: 25%; at least 2.0-fold (0.30 log units) between middle value and limit.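

Within the data shown here, this is the first measured step at the aryl group on the saturated chain carbon, since compound 1 and compound 2 differ only on the amine nitrogen. In this assay, as far as these compounds go, compound 4 gives a limit and not a number, and it shares that limit with compound 1: the limit of > 100000 nM in this assay, at which 2 of the 4 values shown sit. The step to 2-(trifluoromethyl)phenyl from 3-fluorophenyl is an at least 1.8-fold higher number from compound 3 to compound 4 (0.27 log units; that floor lies within the scatter), so the exchange gave no lower number in this assay, though its printed floor does not by itself establish a change beyond the scatter, and its true size stays unknown.

From the compounds shown here alone, what remains open is how far the number of compound 4 lies past the limit, and whether the step belongs to the trifluoromethyl group itself, to its place on the ring, or to the loss of the fluorine of compound 3. Going by these compounds, a ring carrying a chlorine or a methyl group in place of the trifluoromethyl, on the same carboxamide-bearing amine as compound 3 and compound 4, would help separate these readings, and the step from plain phenyl on that amine also stays open.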